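Shortening the linker: from compound 3 to compound 4

The source may hold more compounds than are shown below. What is called first, only, known or untested is meant among the compounds shown, and "the series" means these compounds.

Measured in a functional assay on HepG2 cells (Homo sapiens) for antiproliferative activity, read by CCK-8 assay, with a stated time of 72 h, tested at 8 uM; a higher number here means a stronger effect of the compound at the concentration tested, a lower number a weaker effect:
- compound 1 `CN1CCN(c2nc(Cl)nc3c2ncn3Cc2ccc(C(=O)Nc3ccccc3N)cc2)CC1`: 75%
- compound 2 `Nc1ccccc1NC(=O)/C=C/c1ccc(Cn2cnc3c(Nc4cccc(Cl)c4)nc(Cl)nc32)cc1`: 49.3%
- compound 3 `Nc1ccccc1NC(=O)/C=C/c1ccc(Cn2cnc3c(Nc4ccccc4)nc(Cl)nc32)cc1`: 41.9%

Compound 3 stands lowest of the three numbers. Among the compounds with values here, its nearest neighbour is compound 2, and the single measured step, a number 7.4 percentage points lower from compound 2 to compound 3 (within the scatter), lies within the scatter, so the two cannot be ordered. Compound 1 is furthest away, beyond the scatter higher; as compound 1 differs from compound 3 in two places, its value only shows that a (2-aminophenyl)carbamoyl attached directly to the ring is compatible with a strong effect.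

Compound 4 `Nc1ccccc1NC(=O)c1ccc(Cn2cnc3c(Nc4ccccc4)nc(Cl)nc32)cc1` differs from compound 3 in one place: (2-aminophenyl)carbamoyl in place of 2-((2-aminophenyl)carbamoyl)ethenyl on an aromatic carbon. Within the data shown here, no measured step bears on this change; the one step available concerns the chloro group and stayed within the scatter. Compound 1, which carries the (2-aminophenyl)carbamoyl directly, gives 75%, and this is the only hint toward a higher number. A modest rise is therefore expected, a number 10.1 percentage points higher from compound 3 to compound 4 (beyond the scatter), with wide uncertainty. The estimate for compound 4 is 52%, within 28% to 76%.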

Compound 4, a percentage reported as inhibition, at one concentration (the size of the read-out at that concentration, not a potency): 74.8%
Beside the measured number, compound 4's estimate is 22.8 percentage points below it, within the range that was stated.
By their numbers in this assay, from the lowest: compounds 3 and 2 (each within the scatter of the next); then compounds 4 and 1 (each within the scatter of the next).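

Within the data shown here, on the aromatic carbon para to a large group, (2-aminophenyl)carbamoyl in place of 2-((2-aminophenyl)carbamoyl)ethenyl gives the first single change that clearly moves the read-out in this assay: a number 32.9 percentage points higher from compound 3 to compound 4 (beyond the scatter), whereas the chloro step stayed within the scatter. The second change, anilino in place of 4-methylpiperazin-1-yl, gives a number 0.2 percentage points lower from compound 1 to compound 4 (within the scatter), so with (2-aminophenyl)carbamoyl present these two groups cannot be told apart in this read-out. The data shown offer no explanation for either step.

Going by these compounds, whether chloro on the anilino ring has any effect alongside (2-aminophenyl)carbamoyl remains open. Also open, on these data alone, is how a longer chain or a hydroxamic acid in place of the 2-aminophenyl amide would behave at this position.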